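Carboxybutyl Ether Exchanged for a Nitrophenylsulfonyl Ester

The source may report more compounds than this note shows. Statements on the series, on what has been measured and on what is new or still open speak of the compounds shown alone.

Compound 1, `CCC(CC)(c1ccc(OCCO)c(C)c1)c1ccc(OCC(O)C(C)(C)C)c(OCC(O)C(C)(C)C)c1`: 38%
Compound 2, `CCC(CC)(c1ccc(OCCCO)c(C)c1)c1ccc(OCC(O)C(C)(C)C)c(OCC(O)C(C)(C)C)c1`: 76%
Compound 3, `CCC(CC)(c1ccc(OCCCCC(=O)O)c(C)c1)c1ccc(OCC(O)C(C)(C)C)c(OCC(O)C(C)(C)C)c1`: "not active" (no number reported)

Among the compounds with values here, in an assay on cells for binding affinity to vitamin D3 receptor (Homo sapiens), read by fluorescence, tested at 1 uM (a lower number here means less inhibition, a higher number more inhibition at the concentration tested (going by the name of the read-out)), compound 1 gives 38% and compound 2 gives 76%, and the step of a number 38 percentage points higher from compound 1 to compound 2 (beyond the scatter) is the only measured step in this set. Compound 3 stands apart: in this assay compound 3 is reported as "not active" (no number reported), so no single number describes where it lies. Compound 4, `CCC(CC)(c1ccc(OS(=O)(=O)c2ccc([N+](=O)[O-])cc2)c(C)c1)c1ccc(OCC(O)C(C)(C)C)c(OCC(O)C(C)(C)C)c1`, differs from compound 3 in one place: (4-nitrophenyl)sulfonyl in place of 4-carboxybutyl on an oxygen on an aromatic ring. Within the data shown here, the one measured step concerns a hydroxy against a hydroxymethyl and does not bear on this exchange; no measured step covers it, and compound 3 offers no number from which a step could be taken. The value of compound 4 in this assay is therefore estimated with wide uncertainty at 30%, expected between 0% and 70%.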

Compound 4, a percentage reported as inhibition, at one concentration (the size of the read-out at that concentration, not a potency): 29%
Estimate against measurement, compound 4: 1 percentage points above; measured number inside the range.
By their numbers in this assay, from the lowest: compounds 4 and 1 (each within the scatter of the next); then compound 2.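

In this assay compound 4 gives 29% and so, unlike compound 3, has a number, with (4-nitrophenyl)sulfonyl on the oxygen on an aromatic ring. The exchange gives a number 47 percentage points lower from compound 2 to compound 4 (beyond the scatter) against 3-hydroxypropyl and a number 9 percentage points lower from compound 1 to compound 4 (within the scatter) against 2-hydroxyethyl, so this group, which has no hydrogen-bond donor, falls level with the shorter hydroxy chain and not with the longer one. Nothing available explains these differences.

Going by these compounds, it remains open whether a 4-hydroxybutyl chain or a terminal amine would behave like 3-hydroxypropyl, and whether an unsubstituted phenylsulfonyl group would match (4-nitrophenyl)sulfonyl.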